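Amine chain in place of carbamoyl on compound 3

The source may hold more compounds than are shown below. What is called first, only, known or untested is meant among the compounds shown, and "the series" means these compounds.

Compound 3 `N#Cc1c(NCC(N)=O)sc(C(=O)c2ccc(Br)s2)c1N` gives the highest of the three numbers in an assay for inhibition of Maternal embryonic leucine zipper kinase (Homo sapiens), read by ADP-Glo, with a stated time of 0.5 h (a lower number here means a stronger inhibitor, a higher number a weaker inhibitor), at 540 nM. Compound 2 `N#Cc1c(NCCO)sc(C(=O)c2ccc(Br)s2)c1N` gives 313 nM, and compound 1 `CC(C)Nc1sc(C(=O)c2ccc(Br)s2)c(N)c1C#N` gives 122 nM. The steps read a 2.6-fold higher number from compound 1 to compound 2 (0.41 log units; beyond the scatter) and a 4.4-fold higher number from compound 1 to compound 3 (0.65 log units; beyond the scatter), while a 1.7-fold higher number from compound 2 to compound 3 (0.24 log units; within the scatter) stays within the scatter. Compound 4 `N#Cc1c(NCCCN)sc(C(=O)c2ccc(Br)s2)c1N` differs from compound 3 by 2-aminoethyl in place of carbamoyl on a saturated chain carbon bound to a nitrogen on an aromatic ring. The two steps from compound 1 bear on this change: each chain carrying a donor and an acceptor on the nitrogen gives a higher number than isopropyl, and the two such chains sit within the scatter of each other. Compound 4 is therefore expected to stay near compound 3, with a step of a 1.4-fold lower number from compound 3 to compound 4 (0.13 log units; within the scatter) expected in this assay. Compound 4 is estimated at 400 nM, within 150 nM to 1100 nM.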

Compound 4, half-maximal inhibitory concentration: 141 nM
For compound 4 the middle estimate is 2.8-fold (0.45 log units) above the measured one; the measured number lies below the stated range.
By their numbers in this assay, from the lowest: compounds 1 and 4 (each within the scatter of the next); then compounds 2 and 3 (each within the scatter of the next).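

In this assay the chain ending in an amine separates from the other two chains on the nitrogen: the change gives a 3.8-fold lower number from compound 3 to compound 4 (0.58 log units; beyond the scatter) and a 2.2-fold lower number from compound 2 to compound 4 (0.35 log units; beyond the scatter) at this position. Against isopropyl it gives a 1.2-fold higher number from compound 1 to compound 4 (0.06 log units; within the scatter) here, so compound 4 breaks the earlier reading that chains carrying a donor and an acceptor give a higher number than isopropyl. Nothing in hand accounts for the gap between the amine and the carbamoyl or hydroxy ends.

Open, going by these compounds, is whether the amine depends on this chain length: a shorter 2-aminoethyl or a longer 4-aminobutyl on the nitrogen would test that. Also open, on these data alone, is a carboxylic acid at the chain end.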